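Shortening the side chain on compound 1's ring amine

This account rests on a few compounds, and the source may have more. Where it says the series, first, only, none or still open, it means among the compounds named here.

Within the data shown here, compound 1 `COc1cc(N)c(Cl)cc1NC(=O)C1CCN(Cc2ccc(F)cc2)CC1` is the only compound in this set with a firm number: in a functional assay on the whole organism for antagonist activity, with Mus musculus as the target (a lower number here means that less compound is needed, a higher number that more compound is needed for the effect), compound 1 gives 0.6 mg/kg. The two other measured compounds reached only a limit of the assay. Compound 2 `CCCCCN1CCC(C(=O)Nc2cc(Cl)c(N)cc2OC)CC1` gives > 10 mg/kg in this assay, which is a limit rather than a number. Compound 3 `COc1cccc(CN2CCC(C(=O)Nc3cc(Cl)c(N)cc3OC)CC2)c1` gives > 4 mg/kg in this assay, likewise a limit. Both steps away from compound 1 lose potency: an at least 16-fold higher number from compound 1 to compound 2 (1.22 log units; beyond the scatter), and an at least 6.6-fold higher number from compound 1 to compound 3 (0.82 log units; beyond the scatter).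

Compound 4 `CCCN1CCC(C(=O)Nc2cc(Cl)c(N)cc2OC)CC1` differs from compound 1 in one place (ethyl in place of 4-fluorophenyl on a saturated chain carbon bound to an amine nitrogen in a ring). This closely resembles the change to compound 2, where a butyl replaced the same 4-fluorophenyl and pushed the value to the limit (the limit of > 10 mg/kg in this assay, at which 1 of the 3 values shown sits). A large loss is therefore expected in this assay, in the direction of a higher number. For compound 4 the estimate is 10 mg/kg, in the range 3 mg/kg to 30 mg/kg, which is expected to mean a step of a 17-fold higher number from compound 1 to compound 4 (1.22 log units; beyond the scatter); most likely the assay will again report only a limit.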

Compound 4, dose for half-maximal effect: > 10 mg/kg
Compound 4 gave a limit, no number; the forecaster's own chance of this, stated with the estimate: 65%; the middle value sits exactly at the limit.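

Replacing 4-fluorophenyl with ethyl in this assay gives an at least 16-fold higher number from compound 1 to compound 4 (1.22 log units; beyond the scatter), so this change at the position is as damaging as the earlier change to butyl, as far as the limit can show. Shortening the saturated chain therefore brings back no firm number, and compound 1 remains the only compound here with one. Both chain compounds, compound 2 and compound 4, stop at the same limit: the limit of > 10 mg/kg in this assay, at which 2 of the 4 values shown sit.

The steps from compound 2 and from compound 3 to compound 4 cannot be read, as both ends of each are limits, so the ranking among these three compounds stays unknown. As far as these compounds go, it also stays open whether an unsubstituted phenyl or a 4-chlorophenyl in place of the 4-fluorophenyl would keep a value near that of compound 1.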